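The source may hold more compounds than are shown below. What is called first, only, known or untested is meant among the compounds shown, and "the series" means these compounds.

Measured in an ADME assay on MT4 cells (Homo sapiens) for cytotoxicity, read by MTT assay, with a stated time of 5 days; a higher number here means that more compound is tolerated, a lower number that less compound is tolerated:
- compound 1 (`Cc1cc(C)cc(S(=O)(=O)c2c(C(=O)N[C@H]3CCN(Cc4cccnc4)C3)[nH]c3ccc(Cl)cc23)c1`) gives 22800 nM
- compound 2 (`Cc1cc(C)cc(S(=O)(=O)c2c(C(=O)N[C@H]3CCN(Cc4ccccc4F)C3)[nH]c3ccc(Cl)cc23)c1`) gives 215000 nM
- compound 3 (`Cc1cc(C)cc(S(=O)(=O)c2c(C(=O)N[C@H]3CCN(S(C)(=O)=O)C3)[nH]c3ccc(Cl)cc23)c1`) gives 29900 nM

Compound 3 stands at the low end of this small set together with compound 1, their two values lying within the scatter of each other. The next compound, compound 4 (`Cc1cc(C)cc(S(=O)(=O)c2c(C(=O)NC3CN(Cc4ccccc4F)C3)[nH]c3ccc(Cl)cc23)c1`), differs from compound 3 as follows: 1-(2-fluorobenzyl)azetidin-3-yl in place of 1-(methylsulfonyl)pyrrolidin-3-yl on an amide-type nitrogen. Compound 4 thus carries the 2-fluorobenzyl group also found in compound 2. The closest evidence is a 7.2-fold lower number from compound 2 to compound 3 (0.86 log units; beyond the scatter), which points to a rise when that group returns in place of methylsulfonyl. A second step, a 9.4-fold higher number from compound 1 to compound 2 (0.97 log units; beyond the scatter), also favours the 2-fluorobenzyl compound, whereas a 1.3-fold higher number from compound 1 to compound 3 (0.12 log units; within the scatter) shows no separation. Among the compounds with values here, no measured compound contains the four-membered ring, so only part of the rise seen for compound 2 is assumed. A modest upward step is therefore expected, estimated as a 2.3-fold higher number from compound 3 to compound 4 (0.37 log units; beyond the scatter), with wide uncertainty. For compound 4 the expected value is 70000 nM (estimated range 20000 nM to 220000 nM).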

Compound 4, half-maximal cytotoxic concentration: > 238000 nM
Compound 4: only a limit was reported (the forecaster's own chance of this, stated with the estimate: 10%); at least 3.4-fold (0.53 log units) between middle value and limit.
By their numbers in this assay, from the lowest: compounds 1 and 3 (each within the scatter of the next); then compound 2. At a limit, above all of these: compound 4.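

In this assay compound 4 gives > 238000 nM, which is a limit and not a number. The change to 1-(2-fluorobenzyl)azetidin-3-yl on the amide-type nitrogen gives an at least 7.9-fold higher number from compound 3 to compound 4 (0.90 log units; beyond the scatter) and an at least 10-fold higher number from compound 1 to compound 4 (1.01 log units; beyond the scatter), so the 2-fluorobenzyl group, seen earlier only in compound 2 on a five-membered ring, also goes with a high number on a four-membered ring. Compound 4 is the only compound at such a limit, so both steps are minimum sizes: the limit of > 238000 nM in this assay, at which 1 of the 4 values shown sits.

As far as these compounds go, whether the four-membered ring itself moves the number relative to the five-membered ring of compound 2 stays open, as the two can be set side by side only through a limit. Also open, from the compounds shown here alone, is how the four-membered ring behaves with methylsulfonyl or (pyridin-3-yl)methyl on its nitrogen.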